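This account rests on a few compounds, and the source may have more. Where it says the series, first, only, none or still open, it means among the compounds named here.

Measured compounds in this series:

- compound 1, `CCCc1cnc(C(=O)/C=C/c2ccc(O)cc2)cn1`: 514000 nM
- compound 2, `CCCCc1cnc(C(=O)/C=C/c2ccccc2O)cn1`: 147000 nM

Both numbers come from a functional assay on the whole organism for inhibition, with Chlorella vulgaris as the target, read by spectrophotometry, with a stated time of 4 h; a higher number here means a weaker inhibitor, a lower number a stronger inhibitor. Compound 2 stands at the lower of the two values, with compound 1 giving the higher number, a gap that lies beyond the usual scatter of repeated measurements. Going by the values given here, compound 1 and compound 2 differ in more than one place, so no single step between them is defined.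

The step under consideration goes from compound 2 to compound 3, `CCCCc1cnc(C(=O)/C=C/c2ccc(O)cc2)cn1`, and consists of 4-hydroxyphenyl in place of 2-hydroxyphenyl on a double-bonded chain carbon bound to a double-bonded chain carbon. Nothing else in the molecule changes. Among the compounds with values here, no measured pair in this set isolates this move of the hydroxyl on its own, so the expectation rests only on the two measured values: compound 1, which also carries 4-hydroxyphenyl, gives 514000 nM, while compound 2 with 2-hydroxyphenyl gives 147000 nM. On that basis a step toward a higher number in this assay is expected for compound 3, of moderate size, a 2.0-fold higher number from compound 2 to compound 3 (0.31 log units; beyond the scatter). Compound 3 is accordingly estimated at 300000 nM, with a plausible range from 100000 nM to 900000 nM.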

Compound 3, half-maximal inhibitory concentration: 265000 nM
Compound 3: the middle estimate sits 1.1-fold (0.05 log units) above what was measured; low and high end bracket the measured number.
By their numbers in this assay, from the lowest: compounds 2, 3 and 1 (each within the scatter of the next, the first and the last beyond it).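

In this assay, 4-hydroxyphenyl in place of 2-hydroxyphenyl on a double-bonded chain carbon bound to a double-bonded chain carbon gives a 1.8-fold higher number from compound 2 to compound 3 (0.26 log units; within the scatter) and so does not separate the two hydroxyphenyl groups at this position on the chain of compound 3. Methyl in place of hydrogen on a saturated chain carbon, three bonds along the chain from an aromatic carbon, gives a 1.9-fold lower number from compound 1 to compound 3 (0.29 log units; within the scatter) and thus supplies a second single-place step, also not separated from the scatter, where compounds 1 and 2 alone defined no step at all. No measured property or other supporting data bear on either step, so neither result can be tied to a cause.

Open, as far as these compounds go, is whether 2-hydroxyphenyl and 4-hydroxyphenyl also stay within the scatter of each other on the chain of compound 1, since each step here rests on a single pair. Also open, from the compounds shown here alone, is how 3-hydroxyphenyl or methoxyphenyl at this position, or a hexyl chain on the shared core, would read in this assay and whether any of them would move the number beyond the scatter.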